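Fluoro in place of dimethylamino on compound 1

The source may report more compounds than this note shows. Statements on the series, on what has been measured and on what is new or still open speak of the compounds shown alone.

Compound 1, `COc1cc(OC)c(C(=O)/C=C/c2ccc(N(C)C)cc2)c(O)c1CC=C(C)C`, stands in an ADME assay on MCF7-DOX cells (Homo sapiens) for cytotoxicity, read by MTT assay, with a stated time of 48 h (on this read-out higher numbers stand for weaker inhibition and lower numbers for stronger inhibition), only at a limit: compound 1 gives > 100000 nM, which is a limit of the assay and not a number. Among the two values shown, compound 1 sits at the limit of > 100000 nM in this assay, at which 1 of the 2 values shown sits. Compound 2, `COc1ccc(C(=O)/C=C/c2cccc(N3CCNCC3)c2)c(OC)c1`, is the other measured member; in this assay compound 2 gives 95000 nM. Going by the values given here, no step between measured compounds that differ in one place is available, so no measured step bears on the change under study. Compound 3, `COc1cc(OC)c(C(=O)/C=C/c2ccc(F)cc2)c(O)c1CC=C(C)C`, is not yet measured; its difference from compound 1 reads (fluoro in place of dimethylamino on an aromatic carbon). Among the compounds with values here, with no comparable measured step, the expected step in this assay is none beyond the scatter, in neither direction: the estimated step is a number no higher from compound 1 to compound 3 (the limit leaves the size open). Compound 3 is therefore expected at 100000 nM, with a range from 30000 nM to 300000 nM, and a limit rather than a number is the more likely report in this assay.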

Compound 3, half-maximal inhibitory concentration: 53700 nM
For compound 3 the middle estimate is 1.9-fold (0.27 log units) above the measured one; measured number inside the range.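

In this assay, going by these compounds alone, fluoro in place of dimethylamino, on an aromatic carbon para to a large group, gives an at least 1.8-fold lower number from compound 1 to compound 3 (0.27 log units; that floor lies within the scatter) as the first readable step at this position. As far as these compounds go, compound 1 stands at a limit of the assay and not at a number, so the true size of the step stays open: the limit of > 100000 nM in this assay, at which 1 of the 3 values shown sits. Compound 3 reads as a number, which shows that the core of compound 1 carrying 4-fluorophenyl can return a measured value in this assay and not only a limit.

From the compounds shown here alone, whether the step reflects the loss of dimethylamino or the entry of fluoro stays open, as does whether it reaches beyond the scatter. A chloro, a nitrile or a carboxylic acid on the same aromatic carbon would show whether groups other than fluoro also return a number there.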